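Furan-2-yl for 4-fluorophenyl: working notes on the series

The source may hold more compounds than are shown below. What is called first, only, known or untested is meant among the compounds shown, and "the series" means these compounds.

In a functional assay on HUVEC cells (Homo sapiens) for cytotoxicity (a lower number here means that less compound is needed, a higher number that more compound is needed for the effect), compound 1 `COC1=C(C)C(=O)/C(=C(O)/C=C/c2ccc(OC)cc2)C(=O)C1(C)C` gives 2.5 ug/mL and compound 2 `COC1=C(C)C(=O)/C(=C(O)/C=C/c2ccc(F)cc2)C(=O)C1(C)C` gives 2 ug/mL on the same read-out. Within the data shown here, compound 2 therefore stands level with compound 1: the step, a 1.3-fold lower number from compound 1 to compound 2 (0.10 log units; within the scatter), is the only measured one and swaps fluoro for methoxy on an aromatic carbon without replacing the ring. Compound 3 `COC1=C(C)C(=O)/C(=C(O)/C=C/c2ccco2)C(=O)C1(C)C` has furan-2-yl in place of 4-fluorophenyl on a double-bonded chain carbon bound to a double-bonded chain carbon. No ring replacement has been measured, so the evidence is thin, and no shift beyond the scatter is expected in this assay. The expected change is a 1.3-fold higher number from compound 2 to compound 3 (0.10 log units; within the scatter). For compound 3 the estimated value is 2.5 ug/mL, with an expected range of 1 ug/mL to 6 ug/mL.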

Compound 3, concentration for half-maximal effect: 2.4 ug/mL
Compound 3: the middle estimate sits 1.0-fold (0.02 log units) above what was measured, within the range that was stated.
By their numbers in this assay, from the lowest: compounds 2, 3 and 1 (each within the scatter of the next).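

In this assay, the first ring replacement at this place, on a double-bonded chain carbon bound to a double-bonded chain carbon, leaves the number within the scatter: furan-2-yl in place of 4-fluorophenyl gives a 1.2-fold higher number from compound 2 to compound 3 (0.08 log units; within the scatter) and furan-2-yl in place of 4-methoxyphenyl gives a 1.0-fold lower number from compound 1 to compound 3 (0.02 log units; within the scatter). A five-membered aromatic ring with 1 hetero atom thus reads level with both six-membered aromatic rings of carbon only. No measured property is available to explain this result. As far as these compounds go, all three compounds carry an aromatic ring here, so an amine, a carboxylic acid or a longer chain at this place remains open.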